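Benzylic amine variation in the sulfonamide series

The compounds below may be only part of what the source reports. "The series", "measured", "known", "first", "only" and "open" are said of these compounds alone.

Compound 1 `O=C(C[C@@H]1CCCCN1S(=O)(=O)c1cccc(C(F)(F)F)c1)N[C@@H]1CCCc2cc(CNCC3CC3)ccc21` gives 31 nM in a functional assay for inhibition of B1 bradykinin receptor (Homo sapiens), read by calcium flux; on this read-out lower numbers stand for stronger inhibition and higher numbers for weaker inhibition. For the measured compounds named here, compound 2 `CN(C)Cc1ccc2c(c1)CCC[C@H]2NC(=O)C[C@@H]1CCCCN1S(=O)(=O)c1cccc(C(F)(F)F)c1` gives 160 nM in this assay, the higher of the two numbers so far; the only measured step is a 5.2-fold higher number from compound 1 to compound 2 (0.71 log units; beyond the scatter). Compound 3 `O=C(C[C@@H]1CCCCN1S(=O)(=O)c1cccc(C(F)(F)F)c1)N[C@@H]1CCCc2cc(CN3CCC3)ccc21` differs from compound 2 by azetidin-1-yl in place of dimethylamino on a saturated chain carbon bound to an aromatic carbon. Going by the values given here, only the step from compound 1 to compound 2 bears on this change, and closing the dimethylamino into a small ring is a lesser change than that one, so for compound 3 in this assay a step within the scatter, or at most a small one toward a lower number, is expected, a 1.5-fold lower number from compound 2 to compound 3 (0.16 log units; within the scatter). Compound 3 is expected to give 110 nM, within 40 nM to 300 nM.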

Compound 3, half-maximal inhibitory concentration: 4300 nM
Compound 3: middle estimate off by 39-fold (1.59 log units), on the low side, outside the stated range (above it).
By their numbers in this assay, from the lowest: compound 1; then compound 2; then compound 3.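

In this assay the change to azetidin-1-yl gives a 27-fold higher number from compound 2 to compound 3 (1.43 log units; beyond the scatter) and so weighs far more than the earlier move away from (cyclopropylmethyl)amino. The full span at this place reaches a 140-fold higher number from compound 1 to compound 3 (2.14 log units; beyond the scatter) with only the amine group changed, so inhibition here depends strongly on which amine is carried. Nothing available explains why the four-membered ring gives so much weaker inhibition.

On these data alone, whether the loss belongs to the azetidine alone stays open. Pyrrolidin-1-yl or piperidin-1-yl at the same place would test this, as would a primary aminomethyl group.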